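Swapping the acyl aryl of compound 1 for a trifluoromethylphenyl

The source may hold more compounds than are shown below. What is called first, only, known or untested is meant among the compounds shown, and "the series" means these compounds.

This account follows a single change made to compound 1, whose structure is `CN(C(=O)NC(=O)c1ccc(F)c(F)c1)c1nc(C(F)(F)F)c(C(=O)N/N=C/c2ccc(C(F)(F)F)cc2)s1`. In a functional assay on BCG823 cells (Homo sapiens) for inhibition, read by MTT assay, with a stated time of 72 h (on this read-out higher numbers stand for weaker inhibition and lower numbers for stronger inhibition), compound 1 gives 3.85 ug/mL, which is the highest of the two numbers recorded, though its nearest neighbour is compound 3, `CN(C(=O)NC(=O)c1ccc(F)c(F)c1)c1nc(C(F)(F)F)c(C(=O)N/N=C/c2ccccc2C(F)(F)F)s1`, which in this assay gives 3.66 ug/mL. The move a 1.1-fold lower number from compound 1 to compound 3 (0.02 log units; within the scatter) is a change of 2-(trifluoromethyl)phenyl in place of 4-(trifluoromethyl)phenyl on a carbon with a double bond to nitrogen. Compound 2, `CNc1nc(C)c(C(=O)N/N=C/c2cc(C(F)(F)F)cc(C(F)(F)F)c2)s1`, differs from compound 1 in several places at once, and for it this assay reports only (the limit of > 100 ug/mL in this assay, at which 1 of the 3 values shown sits), a limit of the assay rather than a number; compound 2 gives > 100 ug/mL.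

The unmeasured compound 4 is `CN(C(=O)NC(=O)c1ccc(C(F)(F)F)cc1)c1nc(C(F)(F)F)c(C(=O)N/N=C/c2ccc(C(F)(F)F)cc2)s1`. Its difference from compound 1 is 4-(trifluoromethyl)phenyl in place of 3,4-difluorophenyl on a carbonyl carbon. Among the measured compounds shown here, no measured pair shares this change at the carbonyl carbon, so the only guide is the general tolerance seen in a 1.1-fold lower number from compound 1 to compound 3 (0.02 log units; within the scatter), a step within the scatter at a different position. Compound 4 is therefore expected to sit close to compound 1, with a step of a 1.2-fold higher number from compound 1 to compound 4 (0.07 log units; within the scatter) in this assay. The estimated value for compound 4 is 4.5 ug/mL, with a range from 1.5 ug/mL to 14 ug/mL.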

Compound 4, half-maximal inhibitory concentration: > 100 ug/mL
Compound 4 ended at the assay's limit; the forecaster's own chance of this, stated with the estimate: 10%; middle value at least 22-fold (1.34 log units) away from the limit.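

In this assay, among the compounds shown here, putting 4-(trifluoromethyl)phenyl in place of 3,4-difluorophenyl on a carbonyl carbon gives an at least 25-fold higher number from compound 1 to compound 4 (1.41 log units; beyond the scatter), so the aryl at this carbonyl carbon matters in a way the earlier compounds had not revealed. For the compounds shown here, at the carbon with a double bond to nitrogen, by contrast, the only readable step was a 1.1-fold lower number from compound 1 to compound 3 (0.02 log units; within the scatter). The reading of compound 4, > 100 ug/mL, is a limit of the assay and not a number: the limit of > 100 ug/mL in this assay, at which 2 of the 4 values shown sit.

The groups that leave and enter each hold one six-membered aromatic ring of carbon only and carry no net charge, so what separates them here is the trifluoromethyl group against the two ring fluorines. Going by these compounds, whether the loss belongs to the trifluoromethyl group itself or to the absence of those fluorines stays open, and a single step cannot separate the two. Also open, on these data alone, is how a phenyl carrying one fluorine, a methoxy group or an amine would read on this carbonyl carbon.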